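Metabolic stability across the aminopyridine series

The compounds below may be only part of what the source reports. "The series", "measured", "known", "first", "only" and "open" are said of these compounds alone.

Measured compounds: compound 1 `COc1cccc(Nc2cc3[nH]c(-c4cccc(C(F)(F)F)c4)nc3cn2)n1` gives 60% in an ADME assay on microsomes from liver (Mus musculus) for metabolic stability, read by LC-MS, with a stated time of 30 min, tested at 0.1 uM; on this read-out higher numbers stand for a more stable compound and lower numbers for a less stable compound; compound 2 `COc1cccnc1Nc1cc2[nH]c(-c3cccc(C(F)(F)F)c3)nc2cn1` gives 80%.

Compound 2 holds the higher of the two numbers in this assay, and the gap a number 20 percentage points higher from compound 1 to compound 2 (beyond the scatter) lies beyond the scatter. Compound 3 `FC(F)(F)c1cccc(-c2nc3cnc(Nc4cccnn4)cc3[nH]2)c1` differs from compound 2 by pyridazin-3-yl in place of 3-methoxypyridin-2-yl on a nitrogen on an aromatic ring. No measured step changes this group in the same way; the only step shown exchanged one methoxypyridinyl for another, so it bears on this change only loosely. A change of no more than modest size is expected, a number 8 percentage points lower from compound 2 to compound 3 (within the scatter). Compound 3 is therefore estimated at 72%, within 52% to 90%.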

Compound 3, percent of the compound remaining: 51%
Compound 3: middle estimate off by 21 percentage points, on the high side, and the stated range ends above it.
By their numbers in this assay, from the lowest: compounds 3 and 1 (each within the scatter of the next); then compound 2.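

In this assay, among the compounds shown here, the aromatic group on this nitrogen matters more than the single methoxypyridinyl exchange could show: pyridazin-3-yl in place of 3-methoxypyridin-2-yl gives a number 29 percentage points lower from compound 2 to compound 3 (beyond the scatter). Set against 6-methoxypyridin-2-yl, the same group gives a number 9 percentage points lower from compound 1 to compound 3 (within the scatter). Among these three compounds, only 3-methoxypyridin-2-yl stands apart, so a methoxypyridinyl group alone does not account for the higher number of compound 2.

On these data alone, whether an unsubstituted pyridin-2-yl or a 3-ethoxypyridin-2-yl would keep that number remains open. No measurement at hand gives a reason for the difference between these groups.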